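Swapping the aryl group on the piperidine carbon

A few compounds are considered here, and "the series" means these few. Any claim that something is new, unique, unknown or untested is made for them only; others in the source may bear on it.

Measured compounds:
compound 1 `CN1CCCC(NC(=O)c2ccc(C(F)(F)F)cc2F)(c2ccccc2)C1`, 9900 nM
compound 2 `CSc1cc(C(F)(F)F)ccc1C(=O)NC1(c2ccccc2)CCCN(C)C1`, 67 nM
compound 3 `COc1ccc(C2(NC(=O)c3c(OC)cc(C(F)(F)F)cc3SC)CCCN(C)C2)cc1`, 170 nM

The three measured compounds share a core in which an amide links a substituted benzoyl group to a saturated ring carbon that also carries an aromatic group. In an assay on cells for inhibition of sodium- and chloride-dependent glycine transporter 1 (Homo sapiens) (on this read-out lower numbers stand for an effect already at smaller amounts and higher numbers for an effect only at larger amounts of compound), compound 1 gives 9900 nM, compound 2 gives 67 nM and compound 3 gives 170 nM. Compound 3 therefore stands second highest of the three numbers: compared with compound 2 it gives a higher number, and compared with compound 1 a far lower one. Within the data shown here, the only single-point step among the measured compounds is a 150-fold lower number from compound 1 to compound 2 (2.17 log units; beyond the scatter), which concerns the benzoyl part and not the aromatic group on the saturated ring.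

Compound 4 `COc1cc(C(F)(F)F)cc(SC)c1C(=O)NC1(c2ncccn2)CCCN(C)C1` differs from compound 3 by pyrimidin-2-yl in place of 4-methoxyphenyl on a saturated ring carbon. Among the measured compounds shown here, no measured step touches this position, so the direction of the change cannot be read from the data. Compound 4 is expected to give about 350 nM in this assay, within 80 nM to 1500 nM, amounting to an estimated 2.1-fold higher number from compound 3 to compound 4 (0.31 log units; beyond the scatter).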

Compound 4, half-maximal effective concentration: > 10000 nM
Compound 4: only a limit was reported; the forecaster's own chance of this, stated with the estimate: 5%; middle value at least 28-fold (1.45 log units) away from the limit.
By their numbers in this assay, from the lowest: compound 2; then compound 3; then compound 1. At a limit, above all of these: compound 4.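

Pyrimidin-2-yl in place of 4-methoxyphenyl on a saturated ring carbon brings an at least 58-fold higher number from compound 3 to compound 4 (1.76 log units; beyond the scatter), so this position, which no earlier step touched, does not tolerate every aromatic group. In this assay compound 4 gives > 10000 nM, which is a limit of the assay and not a number. From the compounds shown here alone, the full size of the step therefore stays unknown, and it is bounded from one side only: the limit of > 10000 nM in this assay, at which 1 of the 4 values shown sits.

Since 4-methoxyphenyl gives way to pyrimidin-2-yl as a whole, the compounds shown leave open whether this step goes with the two ring nitrogens that enter or with the methoxy group that leaves. A pyridin-2-yl group or a 4-aminophenyl group at this place would bear on that question.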